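Chain Length on an Oxime Ether of a Quinone Core

The source may hold more compounds than are shown below. What is called first, only, known or untested is meant among the compounds shown, and "the series" means these compounds.

Three close relatives of one quinone core have been measured in a functional assay on L1210 cells (Mus musculus) for antiproliferative activity; on this read-out higher numbers stand for an effect only at larger amounts of compound and lower numbers for an effect already at smaller amounts. Compound 1, `CCCCCCCO/N=C/c1cc(OC)c2c(c1OC)C(=O)C=CC2=O`, gives 0.213 ug/mL. Compound 2, `CCCCCC/C(=N\OCCC)c1cc(OC)c2c(c1OC)C(=O)C=CC2=O`, gives 0.166 ug/mL. Compound 3, `CO/N=C/c1cc(OC)c2c(c1OC)C(=O)C=CC2=O`, gives 0.109 ug/mL, the lowest of the three numbers, yet its gaps to compound 2 and to compound 1 both lie within the scatter, so no order among the three can be claimed.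

Compound 4, `CCCCCO/N=C/c1cc(OC)c2c(c1OC)C(=O)C=CC2=O`, is compound 3 with one change: butyl in place of hydrogen on a saturated chain carbon bound to an oxygen on an unsaturated carbon. Within the data shown here, the one measured step that bears on it runs the other way along the same chain, with a 2.0-fold lower number from compound 1 to compound 3 (0.29 log units; within the scatter); there, removing most of a long chain changed the number only within the scatter. Adding four chain carbons back is therefore expected to move the number little in this assay.

For compound 4 a step of a 1.4-fold higher number from compound 3 to compound 4 (0.14 log units; within the scatter) is expected, that is, no change beyond the scatter. The estimate for compound 4 is 0.15 ug/mL, with a range from 0.07 ug/mL to 0.35 ug/mL, and the measurement will show whether the chain length is indeed indifferent here.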

Compound 4, concentration for half-maximal effect: 0.175 ug/mL
The estimate for compound 4 lay 1.2-fold (0.07 log units) below the measured number; measured number inside the range.
By their numbers in this assay, from the lowest: compounds 3, 2, 4 and 1 (each within the scatter of the next).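

Among these compounds, with compound 4, the chain at this place now has a middle member, so the single earlier step along it can be read in two shorter stages. In this assay, going from methoxy to pentyloxy gives a 1.6-fold higher number from compound 3 to compound 4 (0.21 log units; within the scatter), and shortening the longer chain of compound 1 to pentyloxy gives a 1.2-fold lower number from compound 1 to compound 4 (0.09 log units; within the scatter). Neither stage leaves the scatter, so among these three compounds, adding butyl at this place, or removing ethyl further out along the chain, produces no measurable change, and no point appears along the chain at which the number shifts; nothing available here speaks to why that is.

From the compounds shown here alone, only plain saturated chains on the oxime oxygen can be compared here, so it remains open whether a chain ending in an amine or a carboxylic acid, or one carrying a phenyl ring, would stay within the scatter as well. Going by these compounds, it is equally open whether a much longer chain, or the bare oxime with hydrogen on that oxygen, would move the number beyond the scatter.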